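The source may hold more compounds than are shown below. What is called first, only, known or untested is meant among the compounds shown, and "the series" means these compounds.

Working notes on the series. Compound 1 `C=CC1=C(C(=O)NCCC)C(c2ccc(F)cc2)OC1` is measured in a functional assay on A549 cells (Homo sapiens) for cytotoxicity, read by MTT assay, with a stated time of 24 h; a lower number here means a stronger inhibitor, a higher number a weaker inhibitor. In this assay compound 1 gives only a limit, > 100000 nM. Compound 2 `C=CC1=C(C(=O)NCCC)C(c2ccc(Cl)c(Cl)c2)OC1` in this assay likewise gives only a limit, > 100000 nM. Among the measured compounds shown here, compound 3 `C=CC1=C(C(=O)NCCCCC)C(c2ccc(OC)cc2)OC1` is the one compound of the three with a number, giving 36500 nM in this assay. For the measured compounds named here, two of the three values thus sit at the limit of > 100000 nM in this assay, at which 2 of the 3 values shown sit, and compound 1 stands among them; no step between measured compounds can be drawn, as no pair differs in one place only.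

Compound 4 `C=CC1=C(C(=O)Nc2cccc(C)c2)C(c2ccc(F)cc2)OC1` is not yet measured. It differs from compound 1 by 3-methylphenyl in place of propyl on an amide-type nitrogen; the shared core and the fluorophenyl group are unchanged. Going by the values given here, with compound 1 at a limit, the step to compound 4 cannot be anchored, and the only number, from compound 3, lies close to that limit. The step of an at least 1.6-fold lower number from compound 1 to compound 4 (0.22 log units; that floor lies within the scatter) is expected to be small, likely within the scatter, with a fair chance that the result is again a limit. Compound 4 is expected to give 60000 nM, between 20000 nM and 200000 nM.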

Compound 4, half-maximal inhibitory concentration: > 100000 nM
Compound 4: only a limit was reported; the forecaster's own chance of this, stated with the estimate: 55%; middle value at least 1.6-fold (0.22 log units) away from the limit.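

In this assay compound 4 gives > 100000 nM, which is a limit. Compound 1 is also a limit, so no step between compound 1 and compound 4 can be read: the limit of > 100000 nM in this assay, at which 3 of the 4 values shown sit.

The compounds shown leave open whether 3-methylphenyl in place of propyl on an amide-type nitrogen changes the value at all.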